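One Fluorine Added: What Solubility to Expect

The source may hold more compounds than are shown below. What is called first, only, known or untested is meant among the compounds shown, and "the series" means these compounds.

Measured so far:
Compound 1, `Cc1cc(NCc2cccs2)n2nc(C)c(-c3ccccc3)c2n1`: < 5000 nM
Compound 2, `Cc1cc(NCc2ccccn2)n2ncc(-c3ccccc3C)c2n1`: < 5000 nM

In a physicochemical assay for solubility, read by HPLC, using the shake flask method, measured as kinetic solubility, with a stated time of 2 h, at pH 7.4 (on this read-out lower numbers stand for lower solubility and higher numbers for higher solubility), compound 1 gives < 5000 nM, which is a limit of the assay rather than a number. Compound 2 gives < 5000 nM in this assay, again a limit and not a number. For the measured compounds named here, compound 2 therefore stands at the limit of < 5000 nM in this assay, at which 2 of the 2 values shown sit, alongside the only other compound measured, and the two cannot be told apart on what has been seen. Going by the values given here, compound 1 and compound 2 differ in more than one place, so no single step between them can be read.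

Compound 3, `Cc1cc(NCc2ccccn2)n2ncc(-c3ccc(F)cc3C)c2n1`, is still to be measured in this assay. It differs from compound 2 in one place: fluoro in place of hydrogen on an aromatic carbon. One heavy atom enters and no ring, donor or acceptor is added, so the change is small. Among the compounds with values here, with no measured step to draw on, the step I expect is a step that the limit leaves unreadable from compound 2 to compound 3, that is, none beyond the scatter, and the result would most likely again be reported only as a limit. My estimate for compound 3 in this assay is 2500 nM, within 400 nM to 8000 nM.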

Compound 3, solubility: 42300 nM
Compound 3: middle estimate off by 17-fold (1.23 log units), on the low side; measured number above the stated range.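

In this assay, fluoro on the aromatic carbon para to a large group comes with an at least 8.4-fold higher number from compound 2 to compound 3 (0.92 log units; beyond the scatter). This shows that the position is not a silent one for this read-out, and that a change of one heavy atom, with no ring, donor or acceptor added, can be enough to bring a measurable number out of a limit. Neither earlier compound could show this, since compound 1 and compound 2 differ in more than one place and neither gave a number, and the full size of the step stays unknown because the value for compound 2 is a limit and not a number: the limit of < 5000 nM in this assay, at which 2 of the 3 values shown sit.

This is a single pair, so nothing shown explains the step or tells whether it belongs to fluoro itself or would also appear with another group on the same carbon, such as chloro, methoxy or an amine. As far as these compounds go, it also remains open whether the same change would give a step of this kind on compound 1, which carries a different side chain and a further methyl group on the shared core.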